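Hydrogen for 4-methoxybenzyl on the oxygen of compound 1

The source may report more compounds than this note shows. Statements on the series, on what has been measured and on what is new or still open speak of the compounds shown alone.

Values in a functional assay on SK-MEL cells (Homo sapiens) for cytotoxicity (on this read-out higher numbers stand for weaker inhibition and lower numbers for stronger inhibition), for the series
compound 1 `COc1ccc(CO[C@H]2CC[C@]3(C)C[C@H](Cc4ccccc4C(=O)O)CCC3C2(C)C)cc1` gives 166000 nM
compound 2 `COc1ccc(CO[C@H]2CC[C@]3(C)C[C@H](Cc4cccc(C(=O)O)c4)CCC3C2(C)C)cc1` gives 180000 nM
compound 3 `CC1(C)C2CC[C@@H](Cc3ccccc3C(=O)O)C[C@@]2(C)CC[C@@H]1O` is not yet measured

Compound 1 has only compound 2 as a measured neighbour, and the two cannot be told apart. With 3-carboxyphenyl in place of 2-carboxyphenyl, the result is a 1.1-fold higher number from compound 1 to compound 2 (0.04 log units; within the scatter) and both numbers lie at the weak end of the read-out.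

Compound 3 carries hydrogen in place of 4-methoxybenzyl on an oxygen on a saturated carbon and is otherwise the same as compound 1. Among the compounds with values here, the one measured step concerns the carboxyphenyl group, so it gives no direct guide to this change, and no measured pair tests the loss of 4-methoxybenzyl. Direction therefore remains uncertain. In this assay the expected step is a 1.3-fold higher number from compound 1 to compound 3 (0.12 log units; within the scatter) and this estimate leans only slightly towards a higher number. Compound 3 is estimated at 220000 nM with an expected range of 80000 nM to 600000 nM for its measurement.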

Compound 3, half-maximal inhibitory concentration: 484000 nM
Compound 3: middle estimate off by 2.2-fold (0.34 log units), on the low side; the range from low to high includes it.
By their numbers in this assay, from the lowest: compounds 1 and 2 (each within the scatter of the next); then compound 3.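

In this assay, the change on the oxygen on a saturated carbon gives a 2.9-fold higher number from compound 1 to compound 3 (0.46 log units; beyond the scatter). Within the data shown here, this is the first step to lie beyond the scatter, whereas the move of the carboxyl group gave only a 1.1-fold higher number from compound 1 to compound 2 (0.04 log units; within the scatter), so the oxygen substituent is a place where the read-out responds, though only modestly. Compound 3 still gives a number with no 4-methoxybenzyl on the oxygen, so the presence of a cytotoxicity reading in this series does not depend on that group, and nothing at hand accounts for the size or direction of the step.

The compounds shown leave open whether the same exchange of 4-methoxybenzyl for hydrogen would give a similar step with 3-carboxyphenyl in place of 2-carboxyphenyl. They also leave open which part of 4-methoxybenzyl carries the difference, since an unsubstituted benzyl, a methyl ether or an acetate ester on the same oxygen could show whether the aromatic ring, the methoxy group or simple capping of the hydroxy group matters.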